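Isopropyl for butyl on a purine nitrogen, two cores

The source may hold more compounds than are shown below. What is called first, only, known or untested is meant among the compounds shown, and "the series" means these compounds.

In a functional assay on NCI-H460 cells (Homo sapiens) for antiproliferative activity, read by CCK-8 assay, with a stated time of 72 h, tested at 2 uM (on this read-out higher numbers stand for a stronger effect at the one concentration tested and lower numbers for a weaker effect), compound 1 `CCCCn1cnc2c(Nc3cccc(Cl)c3)nc(NCOCc3ccc(/C=C/C(=O)Nc4ccccc4N)cc3)nc21` gives 25.7% and compound 3 `CC(C)n1cnc2c(Nc3cccc(Cl)c3)nc(NCOCc3ccc(/C=C/C(=O)Nc4ccccc4N)cc3)nc21` gives 53%; the change between them is isopropyl in place of butyl on an aromatic nitrogen and the step is a number 27.3 percentage points higher from compound 1 to compound 3 (beyond the scatter). Compound 2 `CCCCn1cnc2c(NCc3ccc(C(=O)Nc4ccccc4N)cc3)nc(Cl)nc21` gives 19.7% in this assay. The difference between the core of compound 2 and the core of compound 1 is not broken down here. Compound 4 `CC(C)n1cnc2c(NCc3ccc(C(=O)Nc4ccccc4N)cc3)nc(Cl)nc21` carries the same change as compound 3 on the core of compound 2, namely (isopropyl in place of butyl on an aromatic nitrogen). Because compound 3 is separated from compound 1 by a number 27.3 percentage points higher from compound 1 to compound 3 (beyond the scatter), a rise is expected here too, yet the cores differ in more than one place, so the step is estimated somewhat smaller, at a number 16.3 percentage points higher from compound 2 to compound 4 (beyond the scatter). Compound 4 is therefore estimated to reach 36%, most likely between 15% and 60% in this assay.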

Compound 4, a percentage reported as inhibition, at one concentration (the size of the read-out at that concentration, not a potency): 54.2%
Compound 4: middle estimate off by 18.2 percentage points, on the low side; the measured number falls inside the stated range.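

In this assay, isopropyl in place of butyl on an aromatic nitrogen gives a number 34.5 percentage points higher from compound 2 to compound 4 (beyond the scatter), and the step on the other core points the same way, with no difference between the two beyond the scatter: the same change on two cores in this assay, a number 27.3 percentage points higher (beyond the scatter) from compound 1 to compound 3 and a number 34.5 percentage points higher (beyond the scatter) from compound 2 to compound 4, 7.2 percentage points apart, within the scatter of two such steps. Across these two cores, the change therefore carries over in direction and, within that scatter, in size. For the compounds shown here, this rests on only two pairs at a single concentration in one cell line, so it does not show that the change would carry to any further core, nor why the number rises.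

The compounds shown leave open whether a shorter chain such as ethyl, or a ring such as cyclopentyl, on the same nitrogen would give a higher number than isopropyl. They also leave open whether a straight propyl chain would behave like isopropyl or like butyl, so chain length and branching remain unseparated.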